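The source may hold more compounds than are shown below. What is called first, only, known or untested is meant among the compounds shown, and "the series" means these compounds.

Compound 1, `COc1ccc(S(=O)(=O)N2CCc3cccc(NC(=O)c4ccc(C#N)cc4)c32)cc1`, and compound 2, `COc1ccc(S(=O)(=O)N2CCc3cccc(NCc4ccccc4)c32)cc1`, share one core and differ only on a nitrogen on an aromatic ring. In a functional assay on KB cells (Homo sapiens) for cytotoxicity (on this read-out lower numbers stand for stronger inhibition and higher numbers for weaker inhibition), compound 1 gives 105 nM. For compound 2 the same assay reports only a limit, > 10000 nM; this is the limit of > 10000 nM in this assay, at which 1 of the 2 values shown sits, so where compound 2 truly stands is not known. Within the data shown here, the single measured step, an at least 95-fold higher number from compound 1 to compound 2 (1.97 log units; beyond the scatter), therefore records at least that much loss when benzyl replaces (4-cyanophenyl)carbonyl.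

Compound 3, `COc1ccc(S(=O)(=O)N2CCc3cccc(NC(=O)c4ccccc4)c32)cc1`, has not yet been measured in this assay. It differs from compound 2 by benzoyl in place of benzyl on a nitrogen on an aromatic ring. This change restores a carbonyl on that nitrogen, so that compound 3 stands between compound 1 and compound 2: a benzamido group as in compound 1, but without the nitrile of compound 1. Since the measured step bearing on this position is large, compound 3 is expected to return much of what compound 2 lost, a step estimated as an at least 33-fold lower number from compound 2 to compound 3 (1.52 log units; beyond the scatter). Compound 3 is accordingly estimated at 300 nM, with a range from 100 nM to 1500 nM.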

Compound 3, half-maximal inhibitory concentration: 297 nM
Compound 3: the middle estimate sits 1.0-fold (0.00 log units) above what was measured; the measured number falls inside the stated range.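

Replacing benzyl with benzoyl on the nitrogen gives an at least 33-fold lower number from compound 2 to compound 3 (1.52 log units; beyond the scatter) in this assay, so the benzamido group, even without a nitrile, already sets compound 3 far apart from the benzylamino compound 2. This step can be read only as a minimum, because the value of compound 2 is a limit and not a number: the limit of > 10000 nM in this assay, at which 1 of the 3 values shown sits. Among these compounds, the nitrile accounts for a smaller but real part of the activity: hydrogen in place of cyano on an aromatic carbon gives a 2.8-fold higher number from compound 1 to compound 3 (0.45 log units; beyond the scatter), a modest step that is still beyond the scatter, which shows for the first time that the carbonyl and the cyano group can be read separately.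

The compounds shown leave open whether the carbonyl is needed as such or whether another linkage on that nitrogen, such as a urea or a sulfonamide, would serve as well, and whether the phenyl ring of the benzoyl group could give way to a simple acetyl. They also leave open whether a methoxy group, a chlorine or a carboxylic acid in the position of the cyano group would match the nitrile.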